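The source may hold more compounds than are shown below. What is called first, only, known or untested is meant among the compounds shown, and "the series" means these compounds.

In an ADME assay on CHO cells (Cricetulus griseus) for cytotoxicity, read by MTT assay, with a stated time of 72 h (a lower number here means that less compound is tolerated, a higher number that more compound is tolerated), three compounds sharing one core have been measured. Compound 1 `CCOC(=O)c1c(-c2ccc(F)cc2)oc2ccc(OCCN3C(=O)C(=O)c4ccccc43)cc12` gives 128000 nM, compound 2 `CCOC(=O)c1c(-c2ccc(F)cc2)oc2ccc(OCCN3C(=O)C(=O)c4cc(F)ccc43)cc12` gives 64000 nM and compound 3 `CCOC(=O)c1c(-c2ccc(F)cc2)oc2ccc(OCCCN3C(=O)C(=O)c4ccccc43)cc12` gives 256000 nM. Compound 3 is separated from only one of the other two numbers: the data show a 2.0-fold higher number from compound 1 to compound 3 (0.30 log units; within the scatter), but also a 4.0-fold higher number from compound 2 to compound 3 (0.60 log units; beyond the scatter). The fluoro in place of hydrogen on an aromatic carbon gives a 2.0-fold lower number from compound 1 to compound 2 (0.30 log units; within the scatter).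

The next structure is compound 4 `CCOC(=O)c1c(-c2ccc(F)cc2)oc2ccc(OCCCN3C(=O)/C(=N/O)c4ccccc43)cc12`. The change is a group of 12 heavy atoms (8 carbon, 2 nitrogen, 2 oxygen; one five-membered non-aromatic ring with 1 hetero atom, one six-membered aromatic ring of carbon only) in place of a group of 11 heavy atoms (8 carbon, 1 nitrogen, 2 oxygen; one five-membered non-aromatic ring with 1 hetero atom, one six-membered aromatic ring of carbon only), on a saturated chain carbon, three bonds along the chain from an oxygen on an aromatic ring, on a saturated chain carbon, three bonds along the chain from an oxygen on an aromatic ring. Among the compounds with values here, no measured step makes this change, so the three steps above bear on it only indirectly. They show how narrow the range of the series has been so far, and the largest of them is a 4.0-fold higher number from compound 2 to compound 3 (0.60 log units; beyond the scatter). A step of similar size is therefore expected in this assay, weakly favoured downward, since compound 1 at 128000 nM and compound 2 at 64000 nM offer no number beyond compound 3. The estimated step is a 2.0-fold lower number from compound 3 to compound 4 (0.30 log units; within the scatter). With the change untested, the range is kept wide. For compound 4 the estimate is 128000 nM, with an expected range from 40000 nM to 400000 nM.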

Compound 4, half-maximal cytotoxic concentration: 256000 nM
Compound 4: the middle estimate sits 2.0-fold (0.30 log units) below what was measured, and the stated range covers the measured number.
By their numbers in this assay, from the lowest: compounds 2, 1, 3 and 4 (each within the scatter of the next, the first and the last beyond it).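

In this assay, exchanging the 11-heavy-atom group for the 12-heavy-atom group, on a saturated chain carbon, three bonds along the chain from an oxygen on an aromatic ring, gives no change at the digits printed from compound 3 to compound 4 (within the scatter). The entering group has 1 hydrogen-bond donor and 3 hydrogen-bond acceptors, where the leaving group has 0 donors and 2 acceptors, so this place now has one change in those counts, and the number in this assay stays put, at least for this single pair. Nothing available bears on why the number holds here.

The compounds shown leave open whether the same exchange reads alike on the chain of compound 1 or with the aromatic fluoro of compound 2, since this group appears only on the chain of compound 3. They also leave open whether a basic amine, a carboxylic acid or a longer chain at this place would move the number clear of the scatter, or whether the series stays in the same narrow band whatever group stands there.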